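The compounds below may be only part of what the source reports. "The series", "measured", "known", "first", "only" and "open" are said of these compounds alone.

Compound 1 `COc1ccccc1-n1cc(COc2c(/C=C\C(=O)O)ccc(OC)c2CC=C(C)C)nn1` is tested in a functional assay on HCT-116 cells (Homo sapiens) for cytotoxicity, read by MTT assay, with a stated time of 24 h (on this read-out higher numbers stand for weaker inhibition and lower numbers for stronger inhibition), and gives 32200 nM. Compound 2 `COc1ccc(/C=C\C(=O)O)c(OCc2cn(-c3cccc(C#N)c3)nn2)c1CC=C(C)C` differs from it by 3-cyanophenyl in place of 2-methoxyphenyl on an aromatic nitrogen, and in this assay compound 2 gives 35300 nM. The step of a 1.1-fold higher number from compound 1 to compound 2 (0.04 log units; within the scatter) is the only one measured so far, so compound 1 holds the lower of two numbers that are within the scatter of each other.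

Compound 3 `COc1ccc(/C=C\C(=O)O)c(OCc2cn(-c3cccc([N+](=O)[O-])c3)nn2)c1CC=C(C)C` has not yet been measured in this assay. It differs from compound 1 as follows: 3-nitrophenyl in place of 2-methoxyphenyl on an aromatic nitrogen. Among the measured compounds shown here, the one measured step that bears on this change is a 1.1-fold higher number from compound 1 to compound 2 (0.04 log units; within the scatter), which also swaps the group on the same aromatic nitrogen and stays within the scatter. A change of comparable size, with no step beyond the scatter, is therefore expected for compound 3, namely a 1.0-fold higher number from compound 1 to compound 3 (0.01 log units; within the scatter). The estimate for compound 3 in this assay is 33000 nM, expected to lie between 16000 nM and 68000 nM.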

Compound 3, half-maximal inhibitory concentration: 27300 nM
For compound 3 the middle estimate is 1.2-fold (0.08 log units) above the measured one; measured number inside the range.
By their numbers in this assay, from the lowest: compounds 3, 1 and 2 (each within the scatter of the next).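

Putting 3-nitrophenyl in place of 2-methoxyphenyl on this aromatic nitrogen gives a 1.2-fold lower number from compound 1 to compound 3 (0.07 log units; within the scatter), so a second replacement at this position also stays within the scatter in this assay. Nitro in place of cyano on the aromatic carbon gives a 1.3-fold lower number from compound 2 to compound 3 (0.11 log units; within the scatter), which means that these two groups cannot be told apart in this read-out. The three aryl groups shown on this nitrogen therefore give numbers that lie within the scatter of one another, and none of the three compounds stands out.

No measurement at hand explains this flat result. The compounds shown leave open whether a phenyl ring carrying an amine or a hydroxyl group, or a longer alkyl chain in place of the phenyl ring, would move the number beyond the scatter.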